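The source may report more compounds than this note shows. Statements on the series, on what has been measured and on what is new or still open speak of the compounds shown alone.

Measured so far in this series:
compound 1, `CC1Cc2ccccc2N1S(=O)(=O)c1ccc(-c2cnc(C3CC3)o2)cc1`: 81.8%
compound 2, `N#Cc1ccc2c(c1)CCN2S(=O)(=O)c1ccc(-c2cnc(C3CC3)o2)cc1`: 29.6%
compound 3, `O=[N+]([O-])c1ccc2c(c1)N(S(=O)(=O)c1ccc(-c3cnc(C4CC4)o3)cc1)CC2`: 97.7%

In a functional assay on BGC-823 cells (Homo sapiens) for inhibition, read by MTT assay, tested at 10 uM (on this read-out lower numbers stand for less inhibition and higher numbers for more inhibition at the one concentration tested (going by the name of the read-out)), compound 3 gives 97.7% and stands highest of the three numbers. Compound 1 is the nearest, lower by a margin beyond the scatter, and compound 2 is the furthest, lower by a margin well beyond the scatter.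

Compound 4, `O=S(=O)(c1ccc(-c2cnc(C3CC3)o2)cc1)N1CCc2ccc(Cl)cc21`, has not yet been measured in this assay. It differs from compound 3 by chloro in place of nitro on an aromatic carbon. Among the measured compounds shown here, no measured pair shows a change of this kind, so no step size is known for it. A moderate loss beyond the scatter is expected, namely a number 25.7 percentage points lower from compound 3 to compound 4 (beyond the scatter). For compound 4 the estimated inhibition is 72%, with a range from 45% to 95%.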

Compound 4, a percentage reported as inhibition, at one concentration (the size of the read-out at that concentration, not a potency): 87.4%
For compound 4 the middle estimate is 15.4 percentage points below the measured one; low and high end bracket the measured number.
By their numbers in this assay, from the lowest: compound 2; then compounds 1 and 4 (each within the scatter of the next); then compound 3.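

Working notes: in this assay the first single-place change in the series gives a number 10.3 percentage points lower from compound 3 to compound 4 (beyond the scatter) with chloro in place of nitro on the aromatic carbon meta to a fused ring and para to a fused ring. The step is modest, so the nitro group is not required at this position for substantial inhibition at the one concentration tested, although chloro does not fully match it. Nothing available accounts for this step.

Still open, going by these compounds, is how an amine or a carboxylic acid at this position would compare with nitro and chloro. A single pair also cannot show whether this step would hold on a different core.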